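The source may report more compounds than this note shows. Statements on the series, on what has been measured and on what is new or still open speak of the compounds shown alone.

Four compounds share one core, and they differ in two places. Compound 1 `COc1ccc(-c2nc3cc(/C=C4\SC(=O)NC4=O)ccc3[nH]2)cc1OC` carries a hydrogen on the ring nitrogen of its five-membered ring; in a functional assay on A549 cells (Homo sapiens) for inhibition, read by MTT assay, with a stated time of 48 h (on this read-out lower numbers stand for stronger inhibition and higher numbers for weaker inhibition), compound 1 gives 570 nM. Compound 2 `COc1cc(-c2nc3cc(/C=C4\SC(=O)NC4=O)ccc3[nH]2)ccc1OCC(C)C` differs from compound 1 in one place only: isopropyl in place of hydrogen on a saturated chain carbon bound to an oxygen on an aromatic ring. In this assay compound 2 gives 5110 nM, so the step was a 9.0-fold higher number from compound 1 to compound 2 (0.95 log units; beyond the scatter).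

Compound 3 `COc1ccc(-c2nc3cc(/C=C4\SC(=O)N(Cc5cc(OC)c(OC)c(OC)c5)C4=O)ccc3[nH]2)cc1OC` belongs to a second core that differs from the core of compound 1 in more than one place, so the difference between the two cores is not broken down here. In this assay compound 3 gives 130 nM, the lowest number of the three measured compounds.

Compound 4 `COc1cc(-c2nc3cc(/C=C4\SC(=O)N(Cc5cc(OC)c(OC)c(OC)c5)C4=O)ccc3[nH]2)ccc1OCC(C)C` has not yet been measured. It stands to compound 3 exactly as compound 2 stands to compound 1: isopropyl in place of hydrogen on a saturated chain carbon bound to an oxygen on an aromatic ring. The place where the change is made is described in the same words for both pairs, so this is the same change, seen a second time on the other core.

Among the compounds with values here, the only guide to what it may do is the one earlier step, which was modest and beyond the usual scatter. If it carries over, compound 4 is expected to land near 1100 nM, most likely between 400 nM and 3000 nM, because compound 1 moved by a 9.0-fold higher number from compound 1 to compound 2 (0.95 log units; beyond the scatter) when the same change was made. Within the data shown here, that estimate means a step of an 8.5-fold higher number from compound 3 to compound 4 (0.93 log units; beyond the scatter), taken from the one example at hand; whether the second core responds in the same way is what the measurement will show.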

Compound 4, half-maximal inhibitory concentration: 96 nM
For compound 4 the middle estimate is 11-fold (1.06 log units) above the measured one, outside the stated range (below it).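

Going from methoxy to isobutoxy on the core of compound 3 gives, in this assay, a 1.4-fold lower number from compound 3 to compound 4 (0.13 log units; within the scatter), so the clear rise in the number seen on the core of compound 1 does not reappear on this second core. Within the data shown here, the same change therefore behaves differently on the two cores, and the result on one core cannot be assumed to hold on the other: the same change on two cores in this assay, a 9.0-fold higher number (0.95 log units; beyond the scatter) from compound 1 to compound 2 and a 1.4-fold lower number (0.13 log units; within the scatter) from compound 3 to compound 4, 12-fold (1.08 log units) apart, beyond the scatter of two such steps This rests on only two matched pairs in a single assay, and because the two cores differ in more than one place, these compounds do not show which part of the second core accounts for the difference, nor why the change matters on one core and not on the other.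

The compounds shown hold only methoxy and isobutoxy at this place, so it remains open whether the two cores would also part ways with an ethoxy group, a longer chain such as hexyloxy, or a chain ending in an amine or a carboxylic acid. From the compounds shown here alone, it also remains open whether the same difference between the cores would appear in any other cell line or read-out.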